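Dropping the methoxy from a morpholine dithiocarbamate chromone

The source may hold more compounds than are shown below. What is called first, only, known or untested is meant among the compounds shown, and "the series" means these compounds.

Measured so far:
compound 1, `O=c1c(CSC(=S)N2CCCC2)coc2ccccc12`, 3800 nM
compound 2, `O=c1c(CSC(=S)N2CCOCC2)coc2cc(Cl)ccc12`, 600 nM
compound 3, `COc1ccc2occ(CSC(=S)N3CCOCC3)c(=O)c2c1`, > 40000 nM

Of the compounds shown here, three have been tested in a functional assay on MDA-MB-435S cells (Homo sapiens) for antiproliferative activity, read by MTT assay, with a stated time of 72 h; on this read-out lower numbers stand for stronger inhibition and higher numbers for weaker inhibition. Compound 1 gives 3800 nM. Compound 2 gives 600 nM. Within the data shown here, compound 3 gives only the limit > 40000 nM, which is a limit of the assay and not a number, and it is the one value of the three that sits at the limit of > 40000 nM in this assay, at which 1 of the 3 values shown sits. Compound 3 therefore stands at the weak end of what has been measured, with no number of its own.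

Compound 4, `O=c1c(CSC(=S)N2CCOCC2)coc2ccccc12`, has not yet been measured. It differs from compound 3 in one place: hydrogen in place of methoxy on an aromatic carbon, in words, hydrogen in place of methoxy on an aromatic carbon. Among the measured compounds shown here, no measured pair shows this step directly. Compound 1, which also lacks a substituent on that ring, gives a number in this assay, and compound 2 gives a smaller one, so removing the methoxy is expected to move compound 4 toward stronger inhibition by a step well beyond the scatter. The step is estimated as an at least 10-fold lower number from compound 3 to compound 4 (1.00 log units; beyond the scatter). Compound 4 is expected to give about 4000 nM in this assay, within a range of 1200 nM to 20000 nM.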

Compound 4, half-maximal inhibitory concentration: 3900 nM
For compound 4 the middle estimate is 1.0-fold (0.01 log units) above the measured one, and the stated range covers the measured number.
By their numbers in this assay, from the lowest: compound 2; then compounds 1 and 4 (each within the scatter of the next). At a limit, above all of these: compound 3.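

In this assay, the methoxy place now has a reference point: hydrogen in place of methoxy on an aromatic carbon gives an at least 10-fold lower number from compound 3 to compound 4 (1.01 log units; beyond the scatter), a step known only as a bound, as compound 3 holds a limit of the assay and not a number: the limit of > 40000 nM in this assay, at which 1 of the 4 values shown sits.

Compound 4 also provides the unsubstituted partner for compound 2, where hydrogen in place of chloro on an aromatic carbon gives a 6.5-fold higher number from compound 2 to compound 4 (0.81 log units; beyond the scatter), so that among these compounds, methoxy and chloro on this ring stand on opposite sides of hydrogen. At the other end of the molecule, morpholin-4-yl in place of pyrrolidin-1-yl on a thiocarbonyl carbon gives a 1.0-fold higher number from compound 1 to compound 4 (0.01 log units; within the scatter), and the two compounds cannot be told apart on this read-out.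

From the compounds shown here alone, it remains open whether an ethoxy or a hydroxy group on the carbon that carries the methoxy in compound 3 would read like methoxy or like hydrogen, and how chloro would read on that same carbon. Going by these compounds, it is also open whether the match between morpholin-4-yl and pyrrolidin-1-yl extends to piperidin-1-yl or dimethylamino on the thiocarbonyl carbon, or holds on a chloro-bearing core.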